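This account rests on a few compounds, and the source may have more. Where it says the series, first, only, none or still open, it means among the compounds named here.

Measured in a functional assay on A-375 cells (Homo sapiens) for antiproliferative activity, read by MTT assay, with a stated time of 24 h; a lower number here means a stronger inhibitor, a higher number a weaker inhibitor:
- Compound 1 `C#CCOc1ccc2c(=O)c(-c3cc(OC)c(OC)cc3OC)coc2c1`: 3680 nM
- Compound 2 `COc1cccc(C(=O)Oc2ccc3c(=O)c(-c4cc(OC)c(OC)cc4OC)coc3c2)c1`: > 10000 nM
- Compound 3 `COc1cc(OC)c(-c2coc3cc(OCc4ccccc4C)ccc3c2=O)cc1OC`: 1360 nM

The entry for compound 2 is a limit of the assay and not a number. Going by the values given here, only two true numbers therefore exist, and compound 3 holds the lower of them, with compound 1 the nearest at 3680 nM.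

Compound 4 `COc1cc(OC)c(-c2coc3cc(OCc4ccc(C#N)cc4)ccc3c2=O)cc1OC` keeps the core of compound 3 and places 4-cyanophenyl in place of 2-methylphenyl on a saturated chain carbon bound to an oxygen on an aromatic ring.

The closest guide is a 2.7-fold lower number from compound 1 to compound 3 (0.43 log units; beyond the scatter), a modest step made by exchanging the group on that same chain carbon. A much larger change at the oxygen gives an at least 7.3-fold lower number from compound 2 to compound 3 (0.86 log units; beyond the scatter), but there the 2-methylbenzyl group replaces a (3-methoxyphenyl)carbonyl group, so it says less about the present swap. Among the compounds with values here, no measured compound carries a nitrile, so the data give no firm direction. In this assay, a change no larger than the modest one seen for compound 3 seems the reasonable expectation, and probably a smaller one.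

The expected change is a 1.3-fold higher number from compound 3 to compound 4 (0.12 log units; within the scatter), which would not stand beyond the scatter.

For compound 4 the estimated value is 1800 nM, with an expected range from 600 nM to 5500 nM.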

Compound 4, half-maximal inhibitory concentration: 1550 nM
For compound 4 the middle estimate is 1.2-fold (0.06 log units) above the measured one; the measured number falls inside the stated range.
By their numbers in this assay, from the lowest: compounds 3 and 4 (each within the scatter of the next); then compound 1. At a limit, above all of these: compound 2.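

In this assay, putting 4-cyanophenyl in place of 2-methylphenyl on the saturated chain carbon gives a 1.1-fold higher number from compound 3 to compound 4 (0.06 log units; within the scatter), so this position accepts a ring carrying a nitrile as well as one carrying a methyl, with no difference that can be read between them. Going by these compounds alone, the level reached by compound 3 is therefore not tied to the 2-methylphenyl group: replacing ethynyl with 4-cyanophenyl on the same carbon gives a 2.4-fold lower number from compound 1 to compound 4 (0.38 log units; beyond the scatter), a modest step in the same direction as the one seen for compound 3. Exchanging (3-methoxyphenyl)carbonyl for 4-cyanobenzyl on the oxygen gives an at least 6.4-fold lower number from compound 2 to compound 4 (0.80 log units; beyond the scatter), a large step that starts from a limit of the assay and not a number: the limit of > 10000 nM in this assay, at which 1 of the 4 values shown sits.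

The two rings on this chain carbon differ both in their group and in where it sits, so the compounds shown cannot separate those two changes. On these data alone, it also remains open how this position would respond to a ring carrying an amine or a carboxylic acid, or to a longer chain between the oxygen and the ring.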